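The source may hold more compounds than are shown below. What is called first, only, known or untested is meant among the compounds shown, and "the series" means these compounds.

Of the compounds shown here, three of one family have been measured in an assay on H9c2 cells for inhibition of tumor necrosis factor receptor superfamily member 6 (Rattus norvegicus), with stated times of 30 min and 6 h; a lower number here means that less compound is needed, a higher number that more compound is needed for the effect. Compound 1, `COC(=O)c1oc2ccccc2c1NC(=O)CSc1ccc(Br)cc1`, gives 661 nM. Compound 2, `COC(=O)c1sccc1NC(=O)CSc1ccc(OC)cc1`, gives 871 nM. Compound 3, `COC(=O)c1sccc1NC(=O)CCSc1ccc(Br)cc1`, gives 1290 nM. The number for compound 2 sits close to both of the others: the gap to compound 1 and the gap to compound 3 each lie within the usual scatter of this kind of measurement, so the three numbers cannot be told apart with confidence and no ranking among them should be read from these data.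

The next compound, compound 4, `COC(=O)c1sccc1NC(=O)CSc1ccccc1`, has not yet been measured in this assay. It differs from compound 2 in one place: hydrogen in place of methoxy on an aromatic carbon. Among the measured compounds shown here, no pair of measured compounds shows the effect of this exact change, so there is no measured step to lean on. With nothing pointing either way, the expectation is a step from compound 2 to compound 4 of a 1.1-fold higher number from compound 2 to compound 4 (0.04 log units; within the scatter), a change no larger than the scatter and of no certain direction. On that basis, compound 4 is estimated to give 950 nM in this assay, within a range from 400 nM to 2200 nM.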

Compound 4, half-maximal effective concentration: 794 nM
Compound 4: middle estimate off by 1.2-fold (0.08 log units), on the high side; low and high end bracket the measured number.
By their numbers in this assay, from the lowest: compounds 1, 4, 2 and 3 (each within the scatter of the next).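

In this assay, hydrogen in place of methoxy on an aromatic carbon, para to a large group, gives a 1.1-fold lower number from compound 2 to compound 4 (0.04 log units; within the scatter) and so stays within the scatter. Among the compounds shown here, this is the first measured pair in the family that differs in one place, and it shows that this position can lose the methoxy group, with its 2 heavy atoms and 1 hydrogen-bond acceptor, without a change that can be told apart from the usual spread of repeated measurements. Nothing measured here offers an explanation for this result.

The compounds shown leave open whether any group at this position can move the number beyond the scatter, since a single step cannot settle that for groups such as an amine, a carboxylic acid or a nitrile, which may act quite differently from methoxy or hydrogen. They also leave open whether this position would be just as undemanding on the core of compound 1 or with the longer chain of compound 3.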